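A few compounds are considered here, and "the series" means these few. Any claim that something is new, unique, unknown or untested is made for them only; others in the source may bear on it.

Three compounds have been measured in a functional assay on the whole organism with Mus musculus as the target; on this read-out higher numbers stand for an effect only at larger amounts of compound and lower numbers for an effect already at smaller amounts:

- compound 1 `COc1cc2c(cc1OC)C(c1ccc(N)cc1)=NN=C(S)C2`: 3.3 umol/kg
- compound 2 `COc1cc2c(cc1OC)C(c1ccc(Br)cc1)=NNC(=O)C2`: 82.5 umol/kg
- compound 3 `COc1cc2c(cc1OC)C(c1ccc([N+](=O)[O-])cc1)=NN(C)C(=S)C2`: 81.5 umol/kg

Compound 2 and compound 3 sit together at the top of these three numbers, within the usual scatter of each other. Compound 1 lies far lower, well beyond the scatter, so it shows its effect at a much smaller dose.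

The next compound to be tested is compound 4 `COc1cc2c(cc1OC)C(c1cccc(N)c1)=NNC(=O)C2`, which is made from compound 2 by a single change: 3-aminophenyl in place of 4-bromophenyl on a carbon with a double bond to nitrogen. In words, 3-aminophenyl takes the place of 4-bromophenyl on a carbon with a double bond to nitrogen.

Going by the values given here, no measured pair differs in only one place, so the size of this step has to be judged indirectly. Compound 1 also has an amino group on its phenyl ring and gives 3.3 umol/kg, which points towards a lower number. However, compound 1 differs from compound 2 elsewhere too, and no measured compound carries 3-aminophenyl, so only a modest move in that direction is expected in this assay.

The estimate is a 2.4-fold lower number from compound 2 to compound 4 (0.37 log units; beyond the scatter), a step that may stay close to the scatter. For compound 4 the expected value is 35 umol/kg, with an estimated range of 10 umol/kg to 110 umol/kg.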

Compound 4, dose for half-maximal effect: 18.3 umol/kg
Beside the measured number, compound 4's estimate is 1.9-fold (0.28 log units) above it; the range from low to high includes it.
By their numbers in this assay, from the lowest: compound 1; then compound 4; then compounds 3 and 2 (each within the scatter of the next).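

Going by these compounds alone, this is the first pair of compounds that differ in only one place, so the size of a change at this position can be read directly: in this assay, putting 3-aminophenyl in place of 4-bromophenyl on the carbon with a double bond to nitrogen gives a 4.5-fold lower number from compound 2 to compound 4 (0.65 log units; beyond the scatter). The shared core stays the same and the two groups have the same count of heavy atoms, so the choice of ring substituent at this position is enough on its own to shift the dose needed for an effect. What changes within the group is that bromine leaves and a nitrogen enters, bringing a hydrogen-bond donor and a hydrogen-bond acceptor, but no measured property accounts for the shift.

This single step changes both the kind of substituent and where it sits on the phenyl ring, so the two contributions cannot be told apart. Plain phenyl, 3-bromophenyl or 4-aminophenyl on this same core would be needed to separate them.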